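The compounds below may be only part of what the source reports. "The series", "measured", "known", "first", "only" and "open" are said of these compounds alone.

Compound 2 `Cc1ncc([N+](=O)[O-])n1CC(O)CN1CCN(c2ccccc2F)CC1` is the measured anchor for this step. In a toxicity assay on HeLa cells (Homo sapiens) for cytotoxicity, read by MTT assay, with a stated time of 24 h (a higher number here means a weaker inhibitor, a lower number a stronger inhibitor), compound 2 gives > 5000000 nM, which is a limit of the assay rather than a number. Within the data shown here, the only measured step that touches this position comes from compound 1 `CCN1CCN(CC(O)Cn2c([N+](=O)[O-])cnc2C)CC1`, which in this assay gives 4940000 nM; the step of an at least 1.0-fold higher number from compound 1 to compound 2 (0.00 log units; that floor lies within the scatter) changes nothing that the scatter would not cover, and its size rests on (the limit of > 5000000 nM in this assay, at which 1 of the 2 values shown sits). Compound 3 `Cc1ncc([N+](=O)[O-])n1CC(O)CN1CCN(c2cccc(Cl)c2Cl)CC1` carries 2,3-dichlorophenyl in place of 2-fluorophenyl on an amine nitrogen in a ring. Among the measured compounds shown here, no measured step exchanges one substituted phenyl for another on this nitrogen, so the only guide is that a large exchange at this nitrogen left the number at the limit. The expected step of an at least 1.2-fold lower number from compound 2 to compound 3 (0.09 log units; that floor lies within the scatter) is therefore small, with no direction beyond the scatter, and a limit is again quite likely. Compound 3 is estimated at 4000000 nM in this assay, with a range from 1500000 nM to 10000000 nM.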

Compound 3, half-maximal inhibitory concentration: > 5000000 nM
Compound 3: a limit, no number; the forecaster's own chance of this, stated with the estimate: 55%; middle value at least 1.2-fold (0.09 log units) away from the limit.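

In this assay compound 3 gives > 5000000 nM, which is a limit of the assay and not a number, so a second substituted phenyl on this amine nitrogen also ends at a limit, as compound 2 does. Exchanging ethyl for 2,3-dichlorophenyl gives an at least 1.0-fold higher number from compound 1 to compound 3 (0.00 log units; that floor lies within the scatter), while the step between the two phenyl compounds cannot be read. The exchange of 2-fluorophenyl for 2,3-dichlorophenyl therefore yields no readable difference at this position, and the series now rests largely on limits: the limit of > 5000000 nM in this assay, at which 2 of the 3 values shown sit.

As far as these compounds go, whether a carboxylic acid on the phenyl ring, or a longer chain in place of ethyl on this nitrogen, would give a number rather than a limit stays open. From the compounds shown here alone, the order of compound 2 and compound 3 also stays open.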